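The source may hold more compounds than are shown below. What is called first, only, known or untested is meant among the compounds shown, and "the series" means these compounds.

Three compounds from this study share one core, and their largest responses lie close together. Compound 1 `Cc1c(OCCCCOc2ccc(C(=O)O)cc2F)ccc(C(=O)CC2CCCC2)c1O` gives 83.8% in an assay on HEK293 cells for positive allosteric modulation of metabotropic glutamate receptor 2 (Rattus norvegicus), read by thallium flux, with a stated time of 2.5 min; on this read-out higher numbers stand for larger maximal responses and lower numbers for smaller maximal responses. Compound 2 `CCCC(=O)c1ccc(OCCCCOc2ccc(F)c(C(=O)O)c2)c(C)c1O` gives 87.5% in this assay. Compound 3 `COc1cc(C(=O)O)ccc1OCCCCOc1ccc(C(=O)CC(C)C)c(O)c1C` gives 85.7% in this assay. Compound 2 has the highest of the three numbers, yet the gap to compound 3 and the gap to compound 1 both lie within the scatter of repeated measurements, so the three values cannot be told apart.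

Compound 4 `Cc1c(OCCCCOc2ccc(F)c(C(=O)O)c2)ccc(C(=O)CC(C)(C)C)c1O` has not yet been measured in this assay. It differs from compound 2 in one place: tert-butyl in place of ethyl on a saturated chain carbon bound to a carbonyl carbon. Going by the values given here, no step between two measured compounds is available that would show how a change at this place affects the maximal response.

Given that compound 1, compound 2 and compound 3 all sit within the scatter of each other, the step from compound 2 to compound 4 is expected to be a number 2.5 percentage points lower from compound 2 to compound 4 (within the scatter), that is, none beyond the scatter. Compound 4 is therefore expected to reach 85%, with a range from 72% to 96%.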

Compound 4, largest response reached (reported as percent of maximum), in percent of the reference or control that the assay uses: 94.6%
Beside the measured number, compound 4's estimate is 9.6 percentage points below it; measured number inside the range.
By their numbers in this assay, from the lowest: compounds 1, 3, 2 and 4 (each within the scatter of the next, the first and the last beyond it).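

Going by these compounds alone, the step at this place can now be read for the first time: replacing ethyl with tert-butyl on a saturated chain carbon bound to a carbonyl carbon gives, in this assay, a number 7.1 percentage points higher from compound 2 to compound 4 (within the scatter). The change adds two carbons, with no hydrogen-bond donor, acceptor or charge entering or leaving, and the maximal response does not move beyond the scatter, so this place accepts the larger branched group in the setting of compound 2. No measurement shown offers an explanation for this step.

On these data alone, whether a group carrying an amine, a phenyl ring or a longer unbranched chain at this place would leave the maximal response equally unmoved remains open. Also open, as far as these compounds go, is whether the same exchange would give a similar step with the other substituted benzoic acids seen in compound 1 and compound 3.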